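The compounds below may be only part of what the source reports. "The series", "measured", "known", "first", "only" and "open" are said of these compounds alone.

Compound 1 `O=C(CNC(=O)c1ccc(-c2ccccc2)cc1)N/N=C/c1ccccc1OCc1ccccc1Cl`: > 50000 nM, a limit.
Compound 2 `CCN(CC)c1ccc(/C=N/NC(=O)CNC(=O)c2ccc(C)cc2)c(OCc2ccccc2Cl)c1`: > 50000 nM, a limit.

In a functional assay on HepG2 cells (Homo sapiens) for inhibition, read by MTT assay, with a stated time of 24 h (on this read-out higher numbers stand for weaker inhibition and lower numbers for stronger inhibition), compound 1 gives only a limit, > 50000 nM. Compound 2 likewise gives only a limit, > 50000 nM. For the measured compounds named here, neither compound has a numerical value, and the series so far stands at the limit of > 50000 nM in this assay, at which 2 of the 2 values shown sit.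

Compound 3 `N#Cc1ccc(C(=O)NCC(=O)N/N=C/c2ccccc2OCc2ccccc2Cl)cc1` keeps the core of compound 1 and carries one change, cyano in place of phenyl on an aromatic carbon, para to a large group, that is, 4-phenylphenyl to 4-cyanophenyl. Going by the values given here, no step between measured compounds is available as a guide. With compound 1 and compound 2 both setting (the limit of > 50000 nM in this assay, at which 2 of the 2 values shown sit), no shift beyond the scatter is expected in this assay, in either direction, and compound 3 may well read only as a limit too. The estimated step is a number no higher from compound 1 to compound 3 (the limit leaves the size open). For compound 3 the estimated value is 50000 nM, with an expected range of 15000 nM to 100000 nM.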

Compound 3, half-maximal inhibitory concentration: > 50000 nM
Compound 3: no number, only a limit; the forecaster's own chance of this, stated with the estimate: 70%; the middle value lies on the limit itself.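

For the compounds shown here, compound 1 and compound 3 both read only as limits, so no step between them can be read, and the series stays where it was: the limit of > 50000 nM in this assay, at which 3 of the 3 values shown sit. The compounds shown leave open whether any change on the shared core gives a numerical value in this assay rather than a limit.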